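The source may report more compounds than this note shows. Statements on the series, on what has been measured and on what is new or still open speak of the compounds shown alone.

Measured so far:
compound 1 `CCc1cccc2c(OC)c(-c3occ(C)c3COC)ccc12` — 9.7 ug/mL
compound 2 `CCc1cccc2c(OC)c(-c3occ(C)c3COC(C)=O)ccc12` — 3.5 ug/mL
compound 3 `CCOc1c(-c2occ(C)c2COC)ccc2c(CC)cccc12` — > 10 ug/mL

In a functional assay on MDA-MB-231 cells (Homo sapiens) for cytotoxicity, read by MTT assay, with a stated time of 72 h (a higher number here means that more compound is needed for the effect, a lower number that less compound is needed), compound 1 gives 9.7 ug/mL and compound 2 gives 3.5 ug/mL. In this assay compound 3 gives only an assay limit, > 10 ug/mL. Compound 2 carries the change (acetyl in place of methyl on an oxygen on a saturated carbon); this made a 2.8-fold lower number from compound 1 to compound 2 (0.44 log units; beyond the scatter). The core of compound 3 differs from the core of compound 1 by methyl in place of hydrogen on a saturated chain carbon bound to an oxygen on an aromatic ring, and there is an at least 1.0-fold higher number from compound 1 to compound 3 (0.01 log units; that floor lies within the scatter), a floor resting on (the limit of > 10 ug/mL in this assay, at which 1 of the 3 values shown sits). Compound 4 `CCOc1c(-c2occ(C)c2COC(C)=O)ccc2c(CC)cccc12`, not yet measured, carries the same change as compound 2, (acetyl in place of methyl on an oxygen on a saturated carbon), at the same place. Since that change gave a 2.8-fold lower number from compound 1 to compound 2 (0.44 log units; beyond the scatter), a step of similar size is expected for compound 4: an at least 1.6-fold lower number from compound 3 to compound 4 (0.22 log units; that floor lies within the scatter). Compound 4 is therefore expected to give about 6 ug/mL, most likely between 2.5 ug/mL and 15 ug/mL.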

Compound 4, concentration for half-maximal effect: 4.9 ug/mL
Compound 4: the middle estimate sits 1.2-fold (0.09 log units) above what was measured; measured number inside the range.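

Replacing methoxymethyl with acetoxymethyl gives an at least 2.0-fold lower number from compound 3 to compound 4 (0.30 log units; that floor lies within the scatter), the same direction as on the core of compound 1, while methyl in place of hydrogen on the chain carbon bound to the oxygen on the aromatic ring gives a 1.4-fold higher number from compound 2 to compound 4 (0.15 log units; within the scatter). In this assay compound 3 gives only a limit, > 10 ug/mL. The acetyl change therefore points the same way on both cores, but two pairs show no general rule, and whether its size carries over remains unsettled: the same change on two cores in this assay, a 2.8-fold lower number (0.44 log units; beyond the scatter) from compound 1 to compound 2 and an at least 2.0-fold lower number (0.30 log units; that floor lies within the scatter) from compound 3 to compound 4; the limit leaves it open whether they differ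

Going by these compounds, only methyl and acetyl are compared on this oxygen, so an amide or a carboxylic acid in that place remains open. A longer chain on the oxygen on the aromatic ring is also left open.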